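This account rests on a few compounds, and the source may have more. Where it says the series, first, only, none or still open, it means among the compounds named here.

Compound 3, `CC(C)NC(=O)NS(=O)(=O)c1cc(C#N)ccc1Oc1ccc(F)cc1`, stands with the highest number of the three measured in a functional assay on HEK293 cells for antagonist activity at thromboxane A2 receptor (Homo sapiens), read by fluorescence and calcium flux (on this read-out higher numbers stand for weaker inhibition and lower numbers for stronger inhibition), at 9620 nM. Compound 1, `Cc1cccc(Oc2ccc(C#N)cc2S(=O)(=O)NC(=O)NC(C)(C)C)c1`, gives 1050 nM, and compound 2, `Cc1ccc(Oc2ccc(C#N)cc2S(=O)(=O)NC(=O)NC(C)(C)C)cc1`, gives 750 nM. Going by the values given here, the only single-point step measured, a 1.4-fold lower number from compound 1 to compound 2 (0.15 log units; within the scatter), concerns the aryl group and does not bear on the change now at hand. Compound 4, `CC(C)(C)NC(=O)NS(=O)(=O)c1cc(C#N)ccc1Oc1ccc(F)cc1`, arises from compound 3 by methyl in place of hydrogen on a saturated chain carbon bound to an amide-type nitrogen and two saturated chain carbons. Compound 1 and compound 2 both carry the tert-butyl group and both show lower numbers than compound 3, though they also differ from it in the aryl group, so no clean comparison exists. For compound 4 a lower number is expected, with a 3.8-fold lower number from compound 3 to compound 4 (0.59 log units; beyond the scatter), giving an estimated 2500 nM within 800 nM to 8000 nM.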

Compound 4, half-maximal inhibitory concentration: 4350 nM
Estimate against measurement, compound 4: 1.7-fold (0.24 log units) below; the measured number falls inside the stated range.
By their numbers in this assay, from the lowest: compounds 2 and 1 (each within the scatter of the next); then compound 4; then compound 3.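

On this assay, isopropyl to tert-butyl is a modest change that lies beyond the scatter (a 2.2-fold lower number from compound 3 to compound 4 (0.34 log units; beyond the scatter)). With tert-butyl held, the aryl group moves the number further, both for fluoro in place of methyl (a 5.8-fold higher number from compound 2 to compound 4 (0.76 log units; beyond the scatter)) and for 4-fluorophenyl in place of 3-methylphenyl (a 4.1-fold higher number from compound 1 to compound 4 (0.62 log units; beyond the scatter)). Nothing at hand offers an explanation for any of these steps.

The compounds shown leave open whether cyclohexyl or a longer chain in place of tert-butyl would move the number further. They also leave open what chloro or methoxy in place of fluoro would do.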